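A few compounds are considered here, and "the series" means these few. Any claim that something is new, unique, unknown or untested is made for them only; others in the source may bear on it.

Of the compounds shown here, two sharing one core have been tested, and a third awaits measurement. Compound 1 `COc1ccc(-c2cc(=O)c3c(OC)cc(OC)cc3n2Cc2ccccc2)cc1` was examined in a functional assay on HepG2 cells (Homo sapiens) for antiproliferative activity, with a stated time of 72 h; a lower number here means that less compound is needed, a higher number that more compound is needed for the effect. In this assay compound 1 gave only a limit, > 17300 nM. Compound 2 `COc1cc(OC)c2c(=O)cc(C(=O)Nc3ccc(C4CCCCC4)cc3)[nH]c2c1` carries an amide arm that ends in a cyclohexyl group. In this assay compound 2 likewise gave only a limit, > 43100 nM. Compound 2 therefore has no number of its own, and of the two results shown both are limits (the limit of > 17300 nM in this assay, at which 1 of the 2 values shown sits, and (the limit of > 43100 nM in this assay, at which 1 of the 2 values shown sits)), so nothing can yet be ranked. Compound 3 `COc1cc(OC)c2c(=O)cc(C(=O)Nc3ccc(-n4cccc4)cc3)[nH]c2c1` differs from compound 2 in one place: 1H-pyrrol-1-yl in place of cyclohexyl on an aromatic carbon. Among the compounds with values here, no step between measured compounds exists to gauge what this exchange does. Because compound 2 reached only a limit of > 43100 nM, compound 3 is expected to stay near the edge of the tested range, with a step of an at least 1.0-fold lower number from compound 2 to compound 3 (0.03 log units; that floor lies within the scatter) that is expected to show no direction beyond the usual scatter. For compound 3 the estimate is 40000 nM, expected to lie between 10000 nM and 100000 nM, and quite possibly reported again only as a limit.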

Compound 3, half-maximal effective concentration: > 77000 nM
Compound 3: only a limit was reported (the forecaster's own chance of this, stated with the estimate: 65%); middle value at least 1.9-fold (0.28 log units) away from the limit.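

Within the data shown here, compound 2 and compound 3 each gave only a limit in this assay, so no step between them can be read, and the exchange of cyclohexyl for 1H-pyrrol-1-yl has no size or direction here. The compounds shown leave open whether any group on the shared core would give a real number in this assay.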